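This account rests on a few compounds, and the source may have more. Where it says the series, first, only, none or still open, it means among the compounds named here.

Of the compounds shown here, three that share one core have been tested in a functional assay on L02 cells (Homo sapiens) for inhibition; on this read-out higher numbers stand for weaker inhibition and lower numbers for stronger inhibition. Compound 1 `CCN(CC)CCNC(=O)CC(CC(=O)NC1Cc2ccccc2C1)c1ccc(Cl)cc1` gives 76700 nM. Compound 2 `O=C(CC(CC(=O)NC1Cc2ccccc2C1)c1ccccc1)NCCN1CCCCC1` gives only a limit of the assay, > 100000 nM. Compound 3 `CCN(CC)CCNC(=O)CC(CC(=O)NC1Cc2ccccc2C1)c1ccccc1` also gives only a limit, > 100000 nM. Compound 3 therefore has no exact number and stands with the limit of > 100000 nM in this assay, at which 2 of the 3 values shown sit.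

Compound 4 `CCN(CC)CCNC(=O)CC(CC(=O)N(C)C1Cc2ccccc2C1)c1ccccc1` differs from compound 3 in one place: methyl in place of hydrogen on an amide-type nitrogen. In words, this is methyl in place of hydrogen on an amide-type nitrogen.

Among the compounds with values here, no measured pair shows this change, so the two available steps offer only indirect guidance. Hydrogen in place of chloro on an aromatic carbon gives an at least 1.3-fold higher number from compound 1 to compound 3 (0.11 log units; that floor lies within the scatter). Diethylamino in place of piperidin-1-yl gives a step that the two limits leave unreadable from compound 2 to compound 3. Neither step involves the amide-type nitrogen, and neither shows a change beyond the scatter.

No step beyond the scatter is therefore expected in this assay, and another result at the limit is the likeliest outcome. The expected step is a step that the limit leaves unreadable from compound 3 to compound 4. For compound 4 the estimated value is 120000 nM, with an expected range from 60000 nM to 240000 nM.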

Compound 4, half-maximal inhibitory concentration: > 100000 nM
Compound 4: only a limit was reported; the forecaster's own chance of this, stated with the estimate: 75%; the middle value lies beyond the limit too.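

Compound 3 and compound 4 each give only a limit in this assay, not an exact number, so no step can be read between them. That result sits with most of the series: the limit of > 100000 nM in this assay, at which 3 of the 4 values shown sit. The compounds shown leave open what methyl in place of hydrogen on an amide-type nitrogen does to a compound with an exact value, such as compound 1.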